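Swapping the aryl group on the amide nitrogen

The source may report more compounds than this note shows. Statements on the series, on what has been measured and on what is new or still open speak of the compounds shown alone.

Two compounds share a core in which a long alkyl chain sits on a five-membered ring, and an amide carries an aromatic group on its nitrogen. Compound 1 `CCCCCCCCCCCCn1nnc(C(C(=O)Nc2ncccc2C)c2ccccc2)n1` is that core with a methylpyridinyl group on the amide nitrogen; in an assay on liver for inhibition of sterol O-acyltransferase 1 (Rattus norvegicus), using microsomes (on this read-out higher numbers stand for weaker inhibition and lower numbers for stronger inhibition), compound 1 gives 85 nM. Compound 2 `CCCCCCCCCCCCn1nnc(C(C(=O)Nc2c(OC)ncnc2OC)c2ccccc2)n1` carries a dimethoxypyrimidinyl group there instead and in this assay compound 2 gives 13 nM, the lowest of the two numbers, and the step from compound 1 to compound 2 is a 6.5-fold lower number from compound 1 to compound 2 (0.82 log units; beyond the scatter).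

Compound 3 `CCCCCCCCCCCCn1nnc(C(C(=O)Nc2c(C)nn(C)c2C)c2ccccc2)n1` is the next step from compound 2: a group of 8 heavy atoms (6 carbon, 2 nitrogen; one five-membered aromatic ring with 2 hetero atoms) in place of a group of 10 heavy atoms (6 carbon, 2 nitrogen, 2 oxygen; one six-membered aromatic ring with 2 hetero atoms), on an amide-type nitrogen. Within the data shown here, the only measured step touching this position, the one from compound 1 to compound 2, shows that changing the group on the amide nitrogen shifts the number by a modest amount. Which direction the new group takes is open, since no step tests it. Compound 3 is therefore expected to land near compound 2, with the step of a 2.7-fold higher number from compound 2 to compound 3 (0.43 log units; beyond the scatter), and its estimated value is 35 nM, within a range of 8 nM to 150 nM.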

Compound 3, half-maximal inhibitory concentration: 13 nM
Compound 3: middle estimate off by 2.7-fold (0.43 log units), on the high side, within the range that was stated.
By their numbers in this assay, from the lowest: compounds 2 and 3 (each within the scatter of the next); then compound 1.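

In this assay, the 1,3,5-trimethyl-1H-pyrazol-4-yl group and the dimethoxypyrimidinyl group read alike on the amide-type nitrogen, with no change at the digits printed from compound 2 to compound 3 (within the scatter). Set against 3-methylpyridin-2-yl, the same pyrazole group gives a 6.5-fold lower number from compound 1 to compound 3 (0.82 log units; beyond the scatter), so compound 2 is not alone at this level: a five-membered aromatic ring with 2 hetero atoms, 8 heavy atoms and no oxygen matches a six-membered aromatic ring with 2 hetero atoms, 10 heavy atoms and 2 oxygens, which means that neither the larger ring nor its oxygens are required for this reading among these compounds. Nothing available explains why these two different groups match or why both give lower numbers than the group in compound 1.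

The compounds shown leave open how much the three methyl groups on the pyrazole contribute, and how a plain phenyl ring, or a ring carrying an amine or a carboxylic acid, would read on the amide-type nitrogen. All three compounds also share the same long alkyl chain, so they cannot tell whether these groups would still read alike with a shorter chain in its place.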